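This account rests on a few compounds, and the source may have more. Where it says the series, first, only, none or still open, it means among the compounds named here.

Measured so far:
- compound 1 `CO[C@H]1CC[C@H](CN2C(=O)CNc3ncc(-c4ccc(-c5nc[nH]n5)nc4C)nc32)CC1` gives 100%
- compound 2 `Cc1nc(-c2nc[nH]n2)ccc1-c1cnc2c(n1)N(CC1CCOCC1)C(=O)CN2` gives 100%
- compound 3 `Cc1nc(-c2nc[nH]n2)ccc1-c1cnc2c(n1)N(C(C)C)C(=O)CN2` gives 100%

These values come from an ADME assay on S9 fraction from liver (Rattus norvegicus) for metabolic stability, with a stated time of 60 min; a lower number here means that less of the compound is left, a higher number that more of the compound is left. On this read-out, compound 3 stands level with compound 1 and compound 2 at the digits shown.

The next molecule is compound 4 `Cc1nc(-c2nc[nH]n2)ccc1-c1cnc2c(n1)N([C@H]1CC[C@H](O)CC1)C(=O)CN2`. It keeps the shared core and changes one group, with 4-hydroxycyclohexyl in place of isopropyl on an amide-type nitrogen in a ring.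

The most relevant evidence comes from earlier changes to the group on that same nitrogen. These gave no change at the digits printed from compound 1 to compound 3 (within the scatter), no change at the digits printed from compound 2 to compound 3 (within the scatter) and no change at the digits printed from compound 1 to compound 2 (within the scatter). All three steps are flat, so the group on this nitrogen has not yet moved the read-out in any measured pair. That evidence has limits. None of the measured compounds carries the 4-hydroxycyclohexyl group, and with identical values the series has not shown what would lower the number. A small loss therefore cannot be excluded, and the range reaches further down than up.

The estimated step is a number 5 percentage points lower from compound 3 to compound 4 (within the scatter), so no change beyond the scatter is expected.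

For compound 4 the expected value is 95%, with an estimated range from 80% to 100%.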

Compound 4, percent of the compound remaining: 91%
Compound 4: middle estimate off by 4 percentage points, on the high side, and the stated range covers the measured number.
By their numbers in this assay, from the lowest: compounds 4, 1, 2 and 3 (each within the scatter of the next).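

In this assay, the 4-hydroxycyclohexyl group adds a free hydroxyl to the amide-type nitrogen of the ring, and the steps are a number 9 percentage points lower from compound 3 to compound 4 (within the scatter), a number 9 percentage points lower from compound 2 to compound 4 (within the scatter) and a number 9 percentage points lower from compound 1 to compound 4 (within the scatter). Within the data shown here, all three steps stay within the scatter, so this change does not separate compound 4 from the earlier compounds, even though the group that enters has 7 heavy atoms against the 3 of isopropyl and has its six-membered carbon ring bound directly to that nitrogen. The compounds therefore widen the range of groups at this position that give no step beyond the scatter, but nothing here shows what lies behind the small numerical difference.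

Among these compounds, what would produce a real loss at this position remains open, as no step involving this nitrogen has yet gone beyond the scatter. It is also unknown whether an amine or a carboxylic acid on the cyclohexyl ring in place of the hydroxyl, a longer chain on the nitrogen, or the other stereoisomer of the 4-hydroxycyclohexyl group would leave the read-out just as flat.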